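Removing a Methoxy Group from a Dimethoxybenzoyl Hydrazone

A few compounds are considered here, and "the series" means these few. Any claim that something is new, unique, unknown or untested is made for them only; others in the source may bear on it.

Three hydrazones that share a core were run in a functional assay on the whole organism (lung, strain A/J) for inhibition, with Mus musculus as the target, with stated times of 1 h and 18 h, at a dose of 100 umol/kg by the oral route; on this read-out higher numbers stand for more inhibition at the one dose given (going by the name of the read-out) and lower numbers for less inhibition. Compound 1 `COc1ccc(/C=N/N(C)C(=O)c2ccccc2OC)cc1OC` gives 52%, compound 2 `COc1cccc(C(=O)N(C)/N=C/c2ccc(OC)c(OC)c2)c1` gives 73%, and compound 3 `COc1ccc(/C=N/N(C)C(=O)c2ccc(OC)c(OC)c2)cc1OC` gives 53%. Compound 3 thus stands second of the three, with compound 1 within the scatter of it and compound 2 beyond it. Compound 4 `COc1ccc(C(=O)N(C)/N=C/c2ccc(OC)c(OC)c2)cc1` differs from compound 3 in one place: hydrogen in place of methoxy on an aromatic carbon. The step that bears on this is a number 20 percentage points lower from compound 2 to compound 3 (beyond the scatter), the reverse kind of change, though it concerns a different methoxy group; a number 21 percentage points higher from compound 1 to compound 2 (beyond the scatter) shows that where a single methoxy group sits matters. A modest rise is therefore expected, a number 7 percentage points higher from compound 3 to compound 4 (within the scatter). Compound 4 is estimated at 60%, within 40% to 80%, in this assay.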

Compound 4, a percentage reported as inhibition, in the whole organism at one dose (the size of the read-out at that dose, not a potency): 81%
Estimate against measurement, compound 4: 21 percentage points below; measured number above the stated range.
By their numbers in this assay, from the lowest: compounds 1 and 3 (each within the scatter of the next); then compounds 2 and 4 (each within the scatter of the next).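

In this assay, hydrogen in place of the methoxy group ortho to a methoxy group gives a number 28 percentage points higher from compound 3 to compound 4 (beyond the scatter) and so the second methoxy group is not needed for this read-out. Moving the single methoxy group gives a number 8 percentage points higher from compound 2 to compound 4 (within the scatter) and leaves 4-methoxyphenyl and 3-methoxyphenyl unseparated, while a number 29 percentage points higher from compound 1 to compound 4 (beyond the scatter) sets 4-methoxyphenyl clear of 2-methoxyphenyl. No measurement offered here accounts for these steps.

The compounds shown leave open whether a hydroxy group, an amine or a chlorine atom on that ring carbon would keep the number of compound 4. They also leave open how a phenyl ring carrying no methoxy group at all would read.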